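Swapping an azetidine amide for a bare oxadiazole

The compounds below may be only part of what the source reports. "The series", "measured", "known", "first", "only" and "open" are said of these compounds alone.

Compound 2 `CCN1CC(NC(=O)[C@@H]2CCCN(S(=O)(=O)c3ccc(S(=O)(=O)N(CC)CC)cc3)C2)C1` carries a (1-ethylazetidin-3-yl)carbamoyl group on the saturated ring carbon of its shared core. In a functional assay on MIA PaCa-2 cells (Homo sapiens) for inhibition, read by MTT assay, with a stated time of 7 days (a higher number here means a weaker inhibitor, a lower number a stronger inhibitor), compound 2 gives only a limit of the assay, > 30000 nM. Its relative compound 1 `CCN(CC)S(=O)(=O)c1ccc(S(=O)(=O)N2CCC[C@@H](C(=O)NC3CN(C(=O)C4CC4)C3)C2)cc1` gives 2800 nM in this assay, and compound 3 `CCN(CC)S(=O)(=O)c1ccc(S(=O)(=O)N2CCC[C@@H](C(=O)N3CCN(c4nc(C)no4)CC3)C2)cc1` gives 250 nM. The measured steps are all large: an at least 10-fold higher number from compound 1 to compound 2 (1.02 log units; beyond the scatter), an 11-fold lower number from compound 1 to compound 3 (1.05 log units; beyond the scatter) and an at least 120-fold lower number from compound 2 to compound 3 (2.07 log units; beyond the scatter), so the choice of group on the carbonyl carbon, and of the substituent on the azetidine nitrogen, moves the numbers a great deal.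

Compound 4 `CCN(CC)S(=O)(=O)c1ccc(S(=O)(=O)N2CCC[C@@H](c3nc(C)no3)C2)cc1` differs from compound 2 by 3-methyl-1,2,4-oxadiazol-5-yl in place of (1-ethylazetidin-3-yl)carbamoyl on a saturated ring carbon. Within the data shown here, no measured step removes the amide altogether, so the guidance is indirect. Compound 4 shares the 3-methyl-1,2,4-oxadiazol-5-yl group with compound 3, whose gain an at least 120-fold lower number from compound 2 to compound 3 (2.07 log units; beyond the scatter) was large, but it lacks the piperazine amide that compound 3 carries. A gain smaller than that one is expected, an at least 3.0-fold lower number from compound 2 to compound 4 (0.47 log units; beyond the scatter). Compound 4 is therefore estimated at 10000 nM, with a range from 1500 nM to 30000 nM, and a fair chance that only a limit is reported again.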

Compound 4, half-maximal inhibitory concentration: 4100 nM
For compound 4 the middle estimate is 2.4-fold (0.39 log units) above the measured one, within the range that was stated.
By their numbers in this assay, from the lowest: compound 3; then compounds 1 and 4 (each within the scatter of the next). At a limit, above all of these: compound 2.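

Every earlier compound holds a carbonyl on this saturated ring carbon, and compound 4 shows that a measured number does not depend on it: in this assay setting 3-methyl-1,2,4-oxadiazol-5-yl directly on the ring gives an at least 7.3-fold lower number from compound 2 to compound 4 (0.86 log units; beyond the scatter) in a single change. The group that leaves has a hydrogen-bond donor and the group that enters has none, so a donor at this place is not needed for a number to be read. As far as these compounds go, the true size of the step stays unknown because compound 2 stands at a limit of the assay: the limit of > 30000 nM in this assay, at which 1 of the 4 values shown sits.

From the compounds shown here alone, it remains open whether a simple amine or a carboxylic acid on this ring carbon would also give a measurable number. The compounds shown also leave open how a longer chain in place of the methyl on the oxadiazole would fare.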